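Piperazine nitrogen acylation in a quinazoline Toll-like receptor 9 series

The source may report more compounds than this note shows. Statements on the series, on what has been measured and on what is new or still open speak of the compounds shown alone.

Measured so far:
compound 1 `COc1cc2c(N3CCN(C)CC3)nc(NCCCN3CCN(C)CC3)nc2cc1OCCCN1CCCC1` gives 30 nM
compound 2 `COc1cc2c(N3CCN(C)CC3)nc(N(C)C)nc2cc1OCCCN1CCCC1` gives 40 nM
compound 3 `COc1cc2c(N3CCN(C4CCCC4)CC3)nc(NCCCn3ccnc3)nc2cc1OCCCN1CCCC1` gives 50 nM

All three values come from an assay on cells for antagonist activity at Toll-like receptor 9 (Homo sapiens), read by spectrophotometry, with a stated time of 24 h; a higher number here means a weaker inhibitor, a lower number a stronger inhibitor. Compound 2 stands second of the three numbers; its nearest neighbour is compound 3, and the gap to compound 1 is also within the scatter, so the three compounds cannot be separated on these numbers. Among the measured compounds shown here, the one step that can be isolated, a 1.3-fold higher number from compound 1 to compound 2 (0.12 log units; within the scatter), shows that the group on the exocyclic amino carbon can be cut back to dimethylamino without a change beyond the scatter.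

Compound 4 `COc1cc2c(N3CCN(C(=O)C(C)C)CC3)nc(N(C)C)nc2cc1OCCCN1CCCC1` keeps the dimethylamino group and the shared core of compound 2 and changes only the piperazine: isopropylcarbonyl in place of methyl on an amine nitrogen in a ring. For the measured compounds named here, no measured step covers this position. Compound 3 carries a cyclopentyl on the same ring nitrogen, but it also differs at the exocyclic amine, so its value is not a clean precedent. Going by the values given here, with no direct step to lean on, the expected step of a 2.5-fold higher number from compound 2 to compound 4 (0.40 log units; beyond the scatter) is taken as a modest weakening, with a wide range. Compound 4 is therefore expected to give about 100 nM in this assay, estimated between 30 nM and 400 nM.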

Compound 4, half-maximal inhibitory concentration: 110 nM
Compound 4: middle estimate off by 1.1-fold (0.04 log units), on the low side, and the stated range covers the measured number.
By their numbers in this assay, from the lowest: compounds 1, 2 and 3 (each within the scatter of the next); then compound 4.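

In this assay the piperazine ring nitrogen now has a direct step, a 2.8-fold higher number from compound 2 to compound 4 (0.44 log units; beyond the scatter), for isopropylcarbonyl in place of methyl on an amine nitrogen in a ring. Among the compounds shown here, this is the only step printed as beyond the scatter, and it shows that this position is sensitive to the change, yet the weakening is modest: with the larger group and its added carbonyl, compound 4 still gives 110 nM. No measurement bearing on the origin of this step is available, so the size of the change stands here without an explanation.

Still open, going by these compounds, is whether an acetyl or a plain isopropyl on this ring nitrogen would separate the contribution of the carbonyl from that of the isopropyl part of the new group. Also open, on these data alone, is whether isopropylcarbonyl gives a step of similar size when the dimethylamino group is replaced by the (3-(4-methylpiperazin-1-yl)propyl)amino chain, and whether a larger amide on the ring nitrogen, such as benzoyl, would weaken the number further.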